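Chain length and fluorination at the aryl ether end

This account rests on a few compounds, and the source may have more. Where it says the series, first, only, none or still open, it means among the compounds named here.

Measured compounds and their values:
Compound 1, `CCCCOc1ccc(C(CC(=O)O)c2ccccc2)cc1`: 1.2 uM
Compound 2, `CCCCCOc1ccc(C(CC(=O)O)c2ccccc2)cc1`: 2.97 uM
Compound 3, `CCCCCCOc1ccc(C(CC(=O)O)c2ccccc2)cc1`: 2.88 uM

All three compounds share the same core and differ only in the length of the alkyl chain on the aromatic ether oxygen. In a functional assay on HEK293 cells for agonist activity at Free fatty acid receptor 1 (Homo sapiens), read by calcium flux (on this read-out higher numbers stand for an effect only at larger amounts of compound and lower numbers for an effect already at smaller amounts), compound 1 gives 1.2 uM, and lengthening the chain raises the number: a 2.5-fold higher number from compound 1 to compound 2 (0.39 log units; beyond the scatter) and a 2.4-fold higher number from compound 1 to compound 3 (0.38 log units; beyond the scatter). The further extension from the pentyl to the hexyl chain changes nothing that can be told apart, a 1.0-fold lower number from compound 2 to compound 3 (0.01 log units; within the scatter), so compound 2 and compound 3 sit together at the higher end, with compound 1 alone at the lower end.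

Compound 4, `O=C(O)CC(c1ccccc1)c1ccc(OCCCC(F)(F)F)cc1`, has not been measured. Compared with compound 3 the change is trifluoromethyl in place of propyl on a saturated chain carbon, three bonds along the chain from an oxygen on an aromatic ring. The chain thus becomes shorter again, close in length to the butyl chain of compound 1, while gaining three fluorine atoms at its end. For the measured compounds named here, the measured steps speak only to chain length: shortening from hexyl toward butyl would, on its own, point back toward the lower number of compound 1, whereas no measured step tells what the trifluoromethyl group does. The expectation is therefore a small downward step, a 1.4-fold lower number from compound 3 to compound 4 (0.16 log units; within the scatter), which may well remain within the scatter. Compound 4 is estimated at 2 uM, with a range from 0.8 uM to 5 uM.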

Compound 4, concentration for half-maximal effect: 3.16 uM
Estimate against measurement, compound 4: 1.6-fold (0.20 log units) below, within the range that was stated.
By their numbers in this assay, from the lowest: compound 1; then compounds 3, 2 and 4 (each within the scatter of the next).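

The sharpest comparison here is with compound 1, where trifluoromethyl replaces methyl at the end of the chain, three bonds along the chain from an oxygen on an aromatic ring, and this assay gives a step beyond the scatter (a 2.6-fold higher number from compound 1 to compound 4 (0.42 log units; beyond the scatter)). Until now, only added chain carbons had moved the number away from compound 1, whereas this step shows that a change at the chain end with no added chain carbon can do so too, and compound 4 cannot be told apart from the pentyl and hexyl compounds (a 1.1-fold higher number from compound 2 to compound 4 (0.03 log units; within the scatter); a 1.1-fold higher number from compound 3 to compound 4 (0.04 log units; within the scatter)). The compounds shown offer no separate measurement that would explain this shift.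

Going by these compounds, it remains open whether trifluoromethyl has the same effect on shorter or longer chains, as in a 2,2,2-trifluoroethyl, 3,3,3-trifluoropropyl or 5,5,5-trifluoropentyl group. On these data alone, it is also open whether the step needs all three fluorine atoms, or whether a single fluorine atom, a hydroxyl group or a nitrile at the same chain end would give a similar number.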